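Trading 3-Methylphenyl for 4-Chlorophenyl in Compound 3

A few compounds are considered here, and "the series" means these few. Any claim that something is new, unique, unknown or untested is made for them only; others in the source may bear on it.

Among the measured compounds shown here, in a functional assay on PC-3 cells (Homo sapiens) for cytotoxicity, read by MTT assay (on this read-out lower numbers stand for stronger inhibition and higher numbers for weaker inhibition), compound 3 `Cc1cccc(Nc2nc(C)c(C(=O)/C=C/c3ccccc3)s2)c1` gives 11700 nM, the only real number among the three values shown. Compound 1 `Cc1ccc(Nc2nc(C)c(C(=O)/C=C/c3ccccc3)s2)cc1` gives only a limit, > 25000 nM. Compound 2 `COc1cccc(/C=C/C(=O)c2sc(Nc3ccc(Cl)cc3)nc2C)c1` likewise gives only a limit, > 25000 nM. Compound 4 `Cc1nc(Nc2ccc(Cl)cc2)sc1C(=O)/C=C/c1ccccc1` differs from compound 3 by 4-chlorophenyl in place of 3-methylphenyl on a nitrogen on an aromatic ring. For the measured compounds named here, the single measured step that touches this change is an at least 2.1-fold lower number from compound 1 to compound 3 (0.32 log units; beyond the scatter); compound 4 undoes that direction, and compound 2, which also carries 4-chlorophenyl, sits at the limit of > 25000 nM in this assay, at which 2 of the 3 values shown sit. A weakening step is therefore expected for compound 4, most likely ending in a limit rather than a number, with a 2.1-fold higher number from compound 3 to compound 4 (0.33 log units; beyond the scatter) as the estimate. Compound 4 is estimated at 25000 nM, within 9000 nM to 70000 nM.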

Compound 4, half-maximal inhibitory concentration: 24600 nM
Compound 4: middle estimate off by 1.0-fold (0.01 log units), on the high side, within the range that was stated.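

In this assay, among the compounds shown here, 4-chlorophenyl in place of 3-methylphenyl on a nitrogen on an aromatic ring gives a 2.1-fold higher number from compound 3 to compound 4 (0.32 log units; beyond the scatter), the first step on this nitrogen with a real number at both ends. Two further steps, an at least 1.0-fold lower number from compound 2 to compound 4 (0.00 log units; that floor lies within the scatter) and an at least 1.0-fold lower number from compound 1 to compound 4 (0.00 log units; that floor lies within the scatter), cannot be read, because each starts from a limit: the limit of > 25000 nM in this assay, at which 2 of the 4 values shown sit.

The compounds shown leave open whether 3-chlorophenyl or 3-aminophenyl on this nitrogen would give a lower number than compound 3.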